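This account rests on a few compounds, and the source may have more. Where it says the series, first, only, none or still open, it means among the compounds named here.

Measured compounds:
- compound 1 `O=C(Nc1ccccc1)Nc1ccc(Oc2ccc(-c3nccs3)cc2)cc1` — "not determined" (no result reported)
- compound 2 `O=C(Nc1ccc(Oc2ccc(-c3nccs3)cc2)cc1)Nc1ccc(Cl)c([N+](=O)[O-])c1` — 77.1%
- compound 3 `O=C(Nc1ccc(Oc2ccc(-c3ncc[nH]3)cc2)cc1)Nc1ccc(Cl)c([N+](=O)[O-])c1` — 12.4%

In a functional assay on A549 cells (Homo sapiens) for inhibition, read by MTT assay and WST assay, with a stated time of 72 h, tested at 10 uM (a higher number here means more inhibition of growth at the concentration tested, a lower number less inhibition of growth), compound 2 gives 77.1%. The same measurement for compound 3 gives 12.4%, the lowest of the two numbers on record; for compound 1 the entry is "not determined" (no result reported). Within the data shown here, the only single-site step among the measured compounds is the change from compound 2 to compound 3, where 1H-imidazol-2-yl takes the place of 1,3-thiazol-2-yl on an aromatic carbon, and it is a number 64.7 percentage points lower from compound 2 to compound 3 (beyond the scatter).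

Compound 4 `O=C(Nc1ccc(Oc2ccc(-c3ncc[nH]3)cc2)cc1)Nc1cc(C(F)(F)F)ccc1Cl` arises from compound 3 through the change (2-chloro-5-(trifluoromethyl)phenyl in place of 4-chloro-3-nitrophenyl on an amide-type nitrogen). Among the measured compounds shown here, no measured pair touches the aryl group on that amide-type nitrogen; the one recorded step concerns the other end of the molecule and therefore does not bear on this change. The shared core of compound 3 and compound 4 carries the 1H-imidazol-2-yl group, for which only the low number of compound 3 is known.

For the measured compounds named here, with no step to lean on, the expectation for compound 4 in this assay is built around the value of compound 3 and widened on both sides. The estimated step is a number 2.6 percentage points higher from compound 3 to compound 4 (within the scatter), meaning no direction is assumed beyond the scatter. Compound 4 is thus expected to give about 15%, within a range from 0% to 45%.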

Compound 4, percent growth inhibition at one concentration: 22.3%
For compound 4 the middle estimate is 7.3 percentage points below the measured one; low and high end bracket the measured number.
By their numbers in this assay, from the lowest: compounds 3 and 4 (each within the scatter of the next); then compound 2.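

In this assay, the aryl group on the amide-type nitrogen now has a step of its own: with the 1H-imidazol-2-yl group held constant, 2-chloro-5-(trifluoromethyl)phenyl in place of 4-chloro-3-nitrophenyl gives a number 9.9 percentage points higher from compound 3 to compound 4 (within the scatter). The two aryl groups differ in their substituents and in their counted hydrogen-bond acceptors, yet on this one pair the exchange produces no change that can be told from the scatter, so the nitro group is not needed for a number of this size in this series. Nothing available accounts for this result, and it remains a plain observation on a single pair of compounds.

On these data alone, it remains open whether the same aryl exchange would also leave the number in place on the 1,3-thiazol-2-yl side, where compound 2 gives 77.1%, since the step is known only with the 1H-imidazol-2-yl group. The compounds shown also say nothing about how an amine or a carboxylic acid on that aryl ring would behave in this assay.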